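The source may report more compounds than this note shows. Statements on the series, on what has been measured and on what is new or still open speak of the compounds shown alone.

The study concerns a small set of cyclic sulfonate esters built on the shared core of compound 1, `CCC1(Cc2ccccc2)OS(=O)(=O)C=C1OCC#N`. In an ADME assay on HEL cells (Homo sapiens) for cytotoxicity, with a stated time of 3 days (on this read-out higher numbers stand for lower toxicity in this test and lower numbers for higher toxicity in this test), compound 1 gives > 400000 nM, and this is a limit of the test rather than a number, (the limit of > 400000 nM in this assay, at which 1 of the 2 values shown sits). A second member, compound 2, `CCC1(Cc2ccccc2)OS(=O)(=O)C=C1OS(=O)(=O)c1ccc(C)cc1`, has also been measured. In this assay compound 2 gives 400000 nM. Among the measured compounds shown here, no step between these two has been worked out, so all that can be said is that both values sit at the top of what the test reports.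

The account now follows the step from compound 1 to compound 3, `CCC1(Cc2ccccc2)OS(=O)(=O)C=C1OC(=O)c1ccccc1`, whose structure differs from that of compound 1 by benzoyl in place of cyanomethyl on an oxygen on an unsaturated carbon. Nothing in the measured pair points to a direction for this change. The step expected in this test is a number no higher from compound 1 to compound 3 (the limit leaves the size open), which lies within the scatter, because compound 1 already stands at > 400000 nM and the same ceiling is the most likely outcome again. Compound 3 is therefore expected to give about 400000 nM in this assay, with a range from 150000 nM to 400000 nM.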

Compound 3, minimum cytotoxic concentration: > 400000 nM
Compound 3 gave a limit, no number (the forecaster's own chance of this, stated with the estimate: 60%); the middle value lies on the limit itself.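

Compound 1 and compound 3 both end at a limit of the test in this assay, so no step can be read between them for benzoyl in place of cyanomethyl: the limit of > 400000 nM in this assay, at which 2 of the 3 values shown sit.

The compounds shown leave open whether this exchange on the shared core changes the read-out in this assay at all, and by how much.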